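This account rests on a few compounds, and the source may have more. Where it says the series, first, only, none or still open, it means among the compounds named here.

Two compounds have so far been taken into a functional assay on L6 cells (Rattus norvegicus) for cytotoxicity; a higher number here means a weaker inhibitor, a lower number a stronger inhibitor. For compound 1 (`O=c1ccn(CCCO)c(=O)[nH]1`) the entry reads "not determined" (no result reported), so it offers no point of comparison. Among the compounds with values here, compound 2 (`O=c1ccn(CCCCNC(c2ccccc2)(c2ccccc2)c2ccccc2)c(=O)[nH]1`) gives 33000 nM, the only number available, and with nothing to rank it against, it can be placed neither high nor low. Compound 3 (`O=c1ccn(CCC(CO)CNC(c2ccccc2)(c2ccccc2)c2ccccc2)c(=O)[nH]1`) follows from compound 2 by one change, hydroxymethyl in place of hydrogen on a saturated chain carbon bound to two saturated chain carbons. Within the data shown here, no measured pair shows what such a change does in this assay, so no step beyond the scatter is expected, and no direction is favoured. The expected result is a 1.1-fold lower number from compound 2 to compound 3 (0.04 log units; within the scatter). For compound 3 the estimated value is 30000 nM, with an expected range from 12000 nM to 80000 nM.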

Compound 3, half-maximal inhibitory concentration: 55000 nM
Estimate against measurement, compound 3: 1.8-fold (0.26 log units) below, within the range that was stated.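

In this assay, hydroxymethyl in place of hydrogen on a saturated chain carbon bound to two saturated chain carbons gives a 1.7-fold higher number from compound 2 to compound 3 (0.22 log units; within the scatter). Within the data shown here, this is the first measured pair, and it shows that this change at this position produces no step beyond the scatter, so the added hydroxymethyl, with its hydrogen-bond donor and acceptor, leaves the two compounds indistinguishable in this read-out. No available measurement offers an explanation for this outcome.

Going by these compounds, it remains open whether an amine, a carboxylic acid or a longer chain at the same place would produce a step beyond the scatter. On these data alone, with a single pair, it also remains unknown whether hydroxymethyl would behave the same way on another chain carbon or on a different core.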